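A few compounds are considered here, and "the series" means these few. Any claim that something is new, unique, unknown or untested is made for them only; others in the source may bear on it.

Working notes on the series

The shared core is carried by compound 1 `CN1CCN(c2ccc(Nc3ncc4nc(Nc5ccc(F)cc5)n([C@H]5CCCN(S(=O)(=O)C6CC6)C5)c4n3)cc2)CC1`, compound 2 `CN1CCN(c2ccc(Nc3ncc4nc(Nc5ccc(F)cc5)n([C@@H]5CCN(C(=O)OC(C)(C)C)C5)c4n3)cc2)CC1`, compound 3 `CCOC(=O)CN1CC[C@H](n2c(Nc3ccc(F)cc3)nc3cnc(Nc4ccc(N5CCN(C)CC5)cc4)nc32)C1` and the unmeasured compound 4 `CN1CCN(c2ccc(Nc3ncc4nc(Nc5ccc(F)cc5)n([C@H]5CCCN(C(=O)CO)C5)c4n3)cc2)CC1`. In a functional assay on A549 cells (Homo sapiens) for antiproliferative activity, read by MTT assay, with a stated time of 72 h (a lower number here means a stronger inhibitor, a higher number a weaker inhibitor), compound 1 gives 1320 nM. For compound 2 the read-out in this assay is "not determined" (no result reported). Compound 3 stands without a number: in this assay its entry is "not determined" (no result reported), and the other entry without a single number, compound 2, gives no further anchor. Among the compounds with values here, the only measured value in the set is therefore that of compound 1.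

The step from compound 3 to compound 4 is 1-((hydroxymethyl)carbonyl)piperidin-3-yl in place of 1-((ethoxycarbonyl)methyl)pyrrolidin-3-yl on an aromatic nitrogen. Within the data shown here, no measured step between two compounds is known, so its size in this assay cannot be read from the data; a shift beyond the scatter in either direction is not expected, with the value of compound 1 at 1320 nM as the only reference. Compound 4 is estimated at 1100 nM, with a range from 300 nM to 4000 nM.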

Compound 4, half-maximal inhibitory concentration: 830 nM
The estimate for compound 4 lay 1.3-fold (0.12 log units) above the measured number; measured number inside the range.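

The series now has its first readable step at this nitrogen: in this assay, (hydroxymethyl)carbonyl in place of cyclopropylsulfonyl on an amine nitrogen in a ring gives a 1.6-fold lower number from compound 1 to compound 4 (0.20 log units; within the scatter). On the piperidin-3-yl ring, this exchange of a sulfonyl group for a carbonyl group bearing a hydroxymethyl therefore separates the two compounds by no more than the usual scatter, and neither group can be ranked above the other. No separate measurement on these compounds bears on this result or offers a reason for it.

Steps to compound 2 and compound 3 cannot be read, so the comparison of the pyrrolidin-3-yl ring with the piperidin-3-yl ring remains open. Also open, as far as these compounds go, is how a free ring amine, or a carboxylic acid or longer chain on the ring nitrogen, would read in this assay.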